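This account rests on a few compounds, and the source may have more. Where it says the series, first, only, none or still open, it means among the compounds named here.

The measured compounds:
Compound 1, `CCOC(=O)CCCCCOc1cccc(CN(C(=O)c2ccc(-c3ccncc3)cc2)C(C)C)c1`, gives in an ADME assay on HepG2 cells (Homo sapiens) for cytotoxicity, read by CellTiter-Glo and resazurin assay, with a stated time of 72 h (a lower number here means that less compound is needed, a higher number that more compound is needed for the effect), only the limit > 26000 nM.
Compound 2, `CCOC(=O)CCCCCOc1cccc(CN(C(=O)c2ccc(-c3cccc(OC(C)C)c3)cc2)C(C)C)c1`, gives in this assay only the limit > 26000 nM.
Compound 3, `CCOC(=O)CCCCCOc1cccc(CN(C(=O)c2ccc(-c3ccc4cc[nH]c4c3)cc2)C(C)C)c1`, gives in this assay only the limit > 26000 nM.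

Compound 3 stands where the other two stand: its value in this assay is a limit, not a number, and all three of the shown values sit at the limit of > 26000 nM in this assay, at which 3 of the 3 values shown sit. The change to compound 4, `CCOC(=O)CCCCCOc1cccc(CN(C(=O)c2ccc(-c3cccc(CC(=O)O)c3)cc2)C(C)C)c1`, is 3-(carboxymethyl)phenyl in place of 1H-indol-6-yl on an aromatic carbon. The measured steps that bear on it are the other replacements on the same aromatic carbon: a step that the two limits leave unreadable from compound 1 to compound 2, a step that the two limits leave unreadable from compound 1 to compound 3 and a step that the two limits leave unreadable from compound 2 to compound 3. None of them has a readable size; both ends of each rest at the limit of > 26000 nM in this assay, at which 3 of the 3 values shown sit. With every replacement at that aromatic carbon so far leaving the value at the limit, no step beyond the scatter in this assay is expected for compound 4 either. Compound 4 is therefore estimated at 30000 nM, in a range of 15000 nM to 100000 nM, most likely reported again only as a limit. The expected step, a step that the limit leaves unreadable from compound 3 to compound 4, is thus one that is estimated to stay at the limit.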

Compound 4, half-maximal effective concentration: > 26000 nM
Compound 4: a limit, no number; the forecaster's own chance of this, stated with the estimate: 85%; the middle value lies beyond the limit too.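

In this assay the steps to compound 4 from compound 1, compound 2 and compound 3 cannot be read, since all four compounds give a limit and not a number: the limit of > 26000 nM in this assay, at which 4 of the 4 values shown sit.

The compounds shown leave open whether any replacement on this aromatic carbon would give a measurable value in this assay.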